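The compounds below may be only part of what the source reports. "The series", "measured", "known", "first", "only" and "open" are said of these compounds alone.

Measured compounds in a physicochemical assay for lipophilicity, using the shake flask method; a lower number here means a more polar compound, a higher number a more lipophilic compound:
Compound 1, `C=CCO/N=C/c1c(N)ncnc1Oc1ccc(NC(=O)C2(C(=O)Nc3ccc(F)cc3)CC2)cc1F`, gives 3.65.
Compound 2, `Nc1ncnc(Oc2ccc(NC(=O)C3(C(=O)Nc4ccc(F)cc4)CC3)cc2F)c1/C=N/O`, gives 2.62.
Compound 3, `Nc1ncnc(Oc2ccc(NC(=O)C3(C(=O)Nc4ccc(F)cc4)CC3)cc2F)c1/C=N/OCCCO`, gives 2.67.

Compound 2 has the lowest of the three numbers in this assay. Its nearest neighbour is compound 3, and the step of a number 0.05 log units higher from compound 2 to compound 3 (within the scatter) lies within the scatter, so the two compounds cannot be told apart on these numbers. The furthest is compound 1, reached by the step of a number 1.03 log units lower from compound 1 to compound 2 (beyond the scatter) in the reverse direction, which is large and beyond the scatter.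

Compound 4, `Nc1ncnc(Oc2ccc(NC(=O)C3(C(=O)Nc4ccc(F)cc4)CC3)cc2F)c1/C=N/OCC(=O)N1CCOCC1`, has not yet been measured. It differs from compound 2 in one place: ((morpholin-4-yl)carbonyl)methyl in place of hydrogen on an oxygen.

Going by the values given here, two measured steps bear on this change, both at the same oxygen. The step of a number 1.03 log units lower from compound 1 to compound 2 (beyond the scatter) shows that removing allyl from that oxygen lowers the number by a large amount. The step of a number 0.05 log units higher from compound 2 to compound 3 (within the scatter) shows that adding 3-hydroxypropyl to that oxygen changes the number by an amount within the scatter. The change to compound 4 resembles the second more than the first, since the entering group carries two hydrogen-bond acceptors and no hydrogen-bond donors. The expected step of a number 0.02 log units lower from compound 2 to compound 4 (within the scatter) is therefore small, at most a modest move in either direction. For compound 4 the estimate in this assay is 2.6, with a range from 2.1 to 3.1.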

Compound 4, partition coefficient: 2.1
For compound 4 the middle estimate is 0.50 log units above the measured one; low and high end bracket the measured number.
By their numbers in this assay, from the lowest: compound 4; then compounds 2 and 3 (each within the scatter of the next); then compound 1.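

Compound 4 shows that a group on this oxygen can take the number in this assay below the value with hydrogen there, as seen in a number 0.52 log units lower from compound 2 to compound 4 (beyond the scatter). Until now, allyl had stood clearly above hydrogen and 3-hydroxypropyl could not be told apart from it, so the three groups now give three different outcomes at one oxygen, with ((morpholin-4-yl)carbonyl)methyl separated from both 3-hydroxypropyl, in a number 0.57 log units lower from compound 3 to compound 4 (beyond the scatter), and allyl, in a number 1.55 log units lower from compound 1 to compound 4 (beyond the scatter), the widest step seen at this oxygen so far. Nothing in the material at hand accounts for these differences.

The compounds shown do not tell whether the step belongs to the morpholine ring, to the carbonyl or to the two together, since no compound carries one without the other. A piperidin-1-ylcarbonylmethyl group, a dimethylaminocarbonylmethyl group or a carboxylic acid on the same methylene would separate these parts, and a longer chain between the oxygen and the carbonyl would show whether the distance matters.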